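Oxetane replaces the trifluoromethyl-ethyl group on the carbamate

This account rests on a few compounds, and the source may have more. Where it says the series, first, only, none or still open, it means among the compounds named here.

Three measured compounds share one core and differ only in the group on an oxygen next to a carbonyl group. Compound 1 `Cc1nc(S(C)(=O)=O)ccc1Oc1ncnc(OC2CCN(C(=O)OC(C)C)CC2)c1F` gives 77% in a functional assay on isolated protein for inhibition of Glucose-dependent insulinotropic receptor (Rattus norvegicus), read by HTRF and cAMP accumulation; a higher number here means a larger maximal response, a lower number a smaller maximal response. Compound 2 `Cc1nc(S(C)(=O)=O)ccc1Oc1ncnc(OC2CCN(C(=O)O[C@@H](C)CF)CC2)c1F` gives 84% in this assay, and compound 3 `Cc1nc(S(C)(=O)=O)ccc1Oc1ncnc(OC2CCN(C(=O)O[C@@H](C)C(F)(F)F)CC2)c1F` gives 80% in this assay. Compound 3 stands second highest of the three numbers; the steps to its neighbours read a number 3 percentage points higher from compound 1 to compound 3 (within the scatter) and a number 4 percentage points lower from compound 2 to compound 3 (within the scatter), and the remaining step, a number 7 percentage points higher from compound 1 to compound 2 (within the scatter), is also within the scatter. Compound 4 `Cc1nc(S(C)(=O)=O)ccc1Oc1ncnc(OC2CCN(C(=O)OC3(C(F)(F)F)COC3)CC2)c1F` differs from compound 3 by 3-(trifluoromethyl)oxetan-3-yl in place of 1-(trifluoromethyl)ethyl on an oxygen next to a carbonyl group. Within the data shown here, no measured step introduces a ring at this position, so the change is only partly covered, but every fluorine-bearing variation at the oxygen next to a carbonyl group so far has left the maximal response within the scatter. The expected step is therefore small: no change at the digits printed from compound 3 to compound 4 (within the scatter). Compound 4 is estimated to give 80% in this assay, with a range from 70% to 90%.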

Compound 4, largest response reached (reported as efficacy), in percent of the reference or control that the assay uses: 84%
For compound 4 the middle estimate is 4 percentage points below the measured one; the range from low to high includes it.
By their numbers in this assay, from the lowest: compounds 1, 3, 2 and 4 (each within the scatter of the next).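

Placing a ring on this oxygen for the first time leaves the maximal response in this assay within the scatter: the readings are a number 4 percentage points higher from compound 3 to compound 4 (within the scatter), no change at the digits printed from compound 2 to compound 4 (within the scatter) and a number 7 percentage points higher from compound 1 to compound 4 (within the scatter). The 3-(trifluoromethyl)oxetan-3-yl group brings a four-membered ring, a ring oxygen counted as a hydrogen-bond acceptor and no defined stereocentre, so the groups on this oxygen that lie within the scatter of one another now include a ring as well as open chains. Nothing shown bears on why the response holds across these groups.

The compounds shown leave open whether a ring without trifluoromethyl, such as plain oxetan-3-yl, or a cyclobutyl or azetidine ring would also stay within the scatter. They also leave open whether these four compounds, so close in maximal response, stand equally close in the concentration needed to reach it.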